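The compounds below may be only part of what the source reports. "The series", "measured", "known", "first", "only" and "open" are said of these compounds alone.

The measured compounds:
compound 1 `Cn1cc([N+](=O)[O-])cc1C(=O)NNC(=S)Nc1ccc([N+](=O)[O-])cc1` gives 395000 nM in an ADME assay on Vero cells (Chlorocebus sabaeus) for cytotoxicity, read by MTT assay, with a stated time of 72 h; on this read-out lower numbers stand for stronger inhibition and higher numbers for weaker inhibition;
compound 2 `Cn1cc([N+](=O)[O-])cc1C(=O)NNC(=S)Nc1ccc(Cl)cc1` gives 210000 nM in this assay;
compound 3 `O=C(NNC(=S)Nc1ccc([N+](=O)[O-])cc1)c1cc([N+](=O)[O-])c[nH]1` gives 529000 nM in this assay.

Compound 1 and compound 2 differ by chloro in place of nitro on an aromatic carbon, a change that made a step of a 1.9-fold lower number from compound 1 to compound 2 (0.27 log units; within the scatter). Compound 3 shares the substituted aniline of compound 1 but its core differs by hydrogen in place of methyl on an aromatic nitrogen, with a step of a 1.3-fold higher number from compound 1 to compound 3 (0.13 log units; within the scatter). Compound 4 `O=C(NNC(=S)Nc1ccc(Cl)cc1)c1cc([N+](=O)[O-])c[nH]1` is not yet measured; it stands to compound 3 as compound 2 stands to compound 1, differing by chloro in place of nitro on an aromatic carbon, the same change at the same place, which occurs twice among these compounds. Because the earlier step of a 1.9-fold lower number from compound 1 to compound 2 (0.27 log units; within the scatter) was within the scatter, the step from compound 3 to compound 4 is expected to be about a 1.8-fold lower number from compound 3 to compound 4 (0.25 log units; within the scatter). For compound 4 in this assay the estimate is 300000 nM, between 150000 nM and 600000 nM.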

Compound 4, half-maximal inhibitory concentration: 191000 nM
Compound 4: the middle estimate sits 1.6-fold (0.20 log units) above what was measured; low and high end bracket the measured number.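

In this assay, chloro in place of nitro on an aromatic carbon gave a 2.8-fold lower number from compound 3 to compound 4 (0.44 log units; beyond the scatter), and this step agrees with the matching step on the core of compound 1: the same change on two cores in this assay, a 1.9-fold lower number (0.27 log units; within the scatter) from compound 1 to compound 2 and a 2.8-fold lower number (0.44 log units; beyond the scatter) from compound 3 to compound 4, 1.5-fold (0.17 log units) apart, within the scatter of two such steps. Hydrogen in place of methyl on an aromatic nitrogen gave a 1.1-fold lower number from compound 2 to compound 4 (0.04 log units; within the scatter), and this change also carried across the two cores: the same change on two cores in this assay, a 1.3-fold higher number (0.13 log units; within the scatter) from compound 1 to compound 3 and a 1.1-fold lower number (0.04 log units; within the scatter) from compound 2 to compound 4, 1.5-fold (0.17 log units) apart, within the scatter of two such steps. Going by these compounds alone, this rests on only two cores and four compounds, so it does not show that either change would carry to any further core.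

The compounds shown leave open what an amine or a carboxylic acid would give in place of chloro or nitro on the aromatic carbon. They also leave open whether a longer chain in place of methyl on the aromatic nitrogen would behave in the same way.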